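Oxalamide series: aryl halogen swap and cytotoxicity

The source may report more compounds than this note shows. Statements on the series, on what has been measured and on what is new or still open speak of the compounds shown alone.

Compound 1 `Cc1nc(C(NC(=O)C(=O)Nc2ccc(Cl)cc2)C2CCCN2)sc1CO` gives 12400 nM in an ADME assay on TZM-b1 cells (Homo sapiens) for cytotoxicity, read by XTT assay, with a stated time of 3 days; on this read-out lower numbers stand for higher toxicity in this test and higher numbers for lower toxicity in this test. Compound 2 `Cc1nc(C(NC(=O)C(=O)Nc2ccc(Cl)cc2)C2CCCCN2C)sc1CCO` gives 36000 nM in this assay. For compound 3 `Cc1nc(C(NC(=O)C(=O)Nc2ccc(F)c(Cl)c2)C2CCCCN2)sc1CO` only a limit of the assay is recorded, > 77800 nM in this assay. Going by the values given here, compound 3 thus stands at the top of the values shown, being the one value sitting at the limit of > 77800 nM in this assay, at which 1 of the 3 values shown sits. Compound 4 `Cc1nc(C(NC(=O)C(=O)Nc2ccc(F)c(F)c2)C2CCCCN2)sc1CO` differs from compound 3 by fluoro in place of chloro on an aromatic carbon. Among the compounds with values here, no step between two measured compounds is available, so the size of this change has no precedent here. In this assay the expected step is an at least 1.1-fold lower number from compound 3 to compound 4 (0.04 log units; that floor lies within the scatter), none beyond the scatter. Compound 4 is estimated at 70000 nM in this assay, between 30000 nM and 160000 nM, with a limit again likely.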

Compound 4, half-maximal cytotoxic concentration: > 87000 nM
Compound 4 ended at the assay's limit; the forecaster's own chance of this, stated with the estimate: 60%; at least 1.2-fold (0.09 log units) between middle value and limit.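

Compound 3 and compound 4 are both recorded only as limits in this assay; no step can be read between them for fluoro in place of chloro. The compounds shown leave open whether this swap changes the read-out at all.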